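Dimethylamino for Carbamoyl in a Cytotoxicity Series

A few compounds are considered here, and "the series" means these few. Any claim that something is new, unique, unknown or untested is made for them only; others in the source may bear on it.

Measured so far:
compound 1, `Cc1cc(NC(=O)Nc2cccc(C(N)=O)c2)c2ccccc2n1`: > 25000 nM
compound 2, `Cc1cc(NC(=O)Nc2ccc(C(N)=O)cc2)c2ccccc2n1`: > 25000 nM

Both measured compounds come from an ADME assay on BJ cells (Homo sapiens) for cytotoxicity, with a stated time of 72 h; on this read-out lower numbers stand for an effect already at smaller amounts and higher numbers for an effect only at larger amounts of compound. Compound 1 gives only a limit of the assay there, > 25000 nM, and no number. Compound 2 likewise gives only a limit in this assay, > 25000 nM. Compound 1 therefore stands at the limit of > 25000 nM in this assay, at which 2 of the 2 values shown sit, so no ordering between the two measured compounds can be read from the figures.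

The compound still to be measured is compound 3, `Cc1cc(NC(=O)Nc2cccc(N(C)C)c2)c2ccccc2n1`. It differs from compound 1 by dimethylamino in place of carbamoyl on an aromatic carbon. Among the measured compounds shown here, no measured step of this kind exists in the set, so its effect can only be judged from where compound 1 stands. Since compound 1 gives a limit rather than a number in this assay, the step in this assay is expected to be none beyond the scatter, with compound 3 most likely again reported as a limit. The expected step that the limit leaves unreadable from compound 1 to compound 3 is accordingly small. Compound 3 is expected to show 30000 nM in this assay, with a range from 8000 nM to 100000 nM, and this estimate rests on compound 1 because compound 1 gives > 25000 nM.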

Compound 3, half-maximal effective concentration: > 25000 nM
Compound 3 ended at the assay's limit; the forecaster's own chance of this, stated with the estimate: 75%; the middle value is on the limit's open side.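

In this assay compound 3 gives > 25000 nM, which is a limit of the assay and not a number. No step from compound 1 to compound 3 can therefore be read, and dimethylamino in place of carbamoyl stays without a size: the limit of > 25000 nM in this assay, at which 3 of the 3 values shown sit.

The compounds shown leave open at what amount, if any, each would show an effect in this assay.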